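The compounds below may be only part of what the source reports. "The series", "measured", "known", "first", "only" and "open" are said of these compounds alone.

Measured in an ADME assay on C8166 cells (Homo sapiens) for cytotoxicity; on this read-out lower numbers stand for higher toxicity in this test and higher numbers for lower toxicity in this test:
Compound 1 `CCN1C(=O)N(c2ccccc2)C(=O)N(c2ccccc2)c2cc(C(F)(F)F)ccc21`: > 4000 nM, a limit of the assay
Compound 2 `CCN1C(=O)N(c2ccc(O)cc2)C(=O)N(c2ccccc2)c2cc(C(F)(F)F)ccc21`: 35000 nM

Among the compounds with values here, compound 2, at 35000 nM, holds the only actual number in this assay. Compound 3 `CCN1C(=O)N(c2ccc(C)cc2)C(=O)N(c2ccccc2)c2cc(C(F)(F)F)ccc21` differs from it by methyl in place of hydroxy on an aromatic carbon. Within the data shown here, the only measured step at this site is a step that the limit leaves unreadable from compound 1 to compound 2, and it offers no size to carry over. No step beyond the scatter is therefore expected in this assay. The expected step is a 1.8-fold lower number from compound 2 to compound 3 (0.24 log units; within the scatter). For compound 3 the estimated value is 20000 nM, with an expected range of 5000 nM to 60000 nM.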

Compound 3, half-maximal cytotoxic concentration: > 6500 nM
Compound 3 was reported as a limit (the forecaster's own chance of this, stated with the estimate: 40%); the middle value does not contradict the limit.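

In this assay, within the data shown here, compound 3 gives only a limit, > 6500 nM, and no step from compound 1 or compound 2 to compound 3 can be read. The compounds shown leave open how hydrogen, hydroxy and methyl at this site truly compare.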